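The source may report more compounds than this note shows. Statements on the series, on what has been measured and on what is new or still open speak of the compounds shown alone.

Measured compounds:
compound 1, `O=[N+]([O-])c1cc(-c2nnc(SCc3ccccc3)n2Cc2ccccc2)cc([N+](=O)[O-])c1`: > 30000 nM
compound 2, `CCCCCCCCSc1nnc(-c2cc([N+](=O)[O-])cc([N+](=O)[O-])c2)n1Cc1ccccc1`: > 30000 nM

Both measured compounds share the core of compound 1, with a benzyl group and a sulfur-linked chain on it. In an ADME assay on HepG2 cells (Homo sapiens) for cytotoxicity, with a stated time of 48 h (on this read-out lower numbers stand for stronger inhibition and higher numbers for weaker inhibition), compound 1 reaches only the limit of > 30000 nM, so this is a limit and not a number. In this assay compound 2 likewise reaches only the limit of > 30000 nM. The step that the two limits leave unreadable from compound 1 to compound 2 is therefore not readable, and the change of heptyl in place of phenyl on a saturated chain carbon bound to a sulfur left both values at the limit of > 30000 nM in this assay, at which 2 of the 2 values shown sit.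

Compound 3, `O=[N+]([O-])c1cc(-c2nnc(SCc3ccc(Br)cc3)n2Cc2ccccc2)cc([N+](=O)[O-])c1`, differs from compound 2 by 4-bromophenyl in place of heptyl on a saturated chain carbon bound to a sulfur. Within the data shown here, the only measured step bearing on this change is a step that the two limits leave unreadable from compound 1 to compound 2, which shows no readable size in either direction. The shown numbers give no ground for expecting compound 3 to leave the limit. Compound 3 is therefore estimated in this assay at 40000 nM, with a range from 15000 nM to 120000 nM. This estimate corresponds to an expected step that the limit leaves unreadable from compound 2 to compound 3, that is, none beyond the scatter.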

Compound 3, half-maximal inhibitory concentration: > 30000 nM
Compound 3 ended at the assay's limit; the forecaster's own chance of this, stated with the estimate: 80%; the middle value lies beyond the limit too.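

No new step can be read in this assay between compound 3 and either compound 1 or compound 2, as all three compounds give a limit and not a number: the limit of > 30000 nM in this assay, at which 3 of the 3 values shown sit. The compounds shown leave open how far their true values lie apart, and whether any group on the sulfur would bring a value within the range of this assay.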